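The source may hold more compounds than are shown below. What is called first, only, known or untested is meant among the compounds shown, and "the series" means these compounds.

Working notes on the series. Compound 1 `COc1ccc(OCCCON2C(N)=NC(N)=NC23CCOCC3)cc1` is the starting point; in an assay on isolated protein for inhibition of Dihydrofolate reductase (Homo sapiens), read by spectrophotometry, using NADPH, with stated times of 5 s and 6 min, tested at 50 uM (a lower number here means a weaker effect, a higher number a stronger effect of the compound at the concentration tested), compound 1 has "not determined" (no result reported), so no number places it. Compound 3 `NC1=NC2(CCSCC2)N(OCCCOc2ccc(Br)cc2)C(N)=N1` likewise shows "not determined" (no result reported) in this assay. Within the data shown here, the only number comes from compound 2 `NC1=NC2(CCSCC2)N(OCCCOc2cccc(Cl)c2)C(N)=N1`, which in this assay gives 88.8%. Compound 4 `NC1=NC2(CCOCC2)N(OCCCOc2ccccc2Cl)C(N)=N1` is not yet measured. It differs from compound 1 by 2-chlorophenyl in place of 4-methoxyphenyl on an oxygen on a saturated carbon. Among the measured compounds shown here, no measured pair with this change exists, so the size and direction of the step cannot be read from the data; compound 2 remains the only anchor for the series. Compound 4 is expected to give about 78% in this assay, with a range from 50% to 97%.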

Compound 4, a percentage reported as inhibition, at one concentration (the size of the read-out at that concentration, not a potency): 88.2%
Compound 4: middle estimate off by 10.2 percentage points, on the low side, and the stated range covers the measured number.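

Among these compounds, compound 1 has "not determined" (no result reported) in this assay, and no step to compound 4 can be read. On these data alone, the effect of 2-chlorophenyl in place of 4-methoxyphenyl stays open. No evidence on this result is available.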